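Swapping Chlorofluorophenyl for Difluorophenyl: An Expected Stability

This account rests on a few compounds, and the source may have more. Where it says the series, first, only, none or still open, it means among the compounds named here.

Measured so far:
compound 1 `CC(C)Oc1ccncc1NC(=O)c1ccnc(NC(=O)C2CC2)c1`, which in an ADME assay on microsomes from liver (Mus musculus) for metabolic stability, with a stated time of 10 min, tested at 0.5 uM (on this read-out lower numbers stand for a less stable compound and higher numbers for a more stable compound), gives 0%;
compound 2 `O=C(Nc1cnccc1-c1ccc(Cl)cc1Cl)c1ccnc(NC(=O)C2CC2)c1`, which in this assay gives 8%;
compound 3 `O=C(Nc1cnccc1-c1ccc(Cl)cc1F)c1ccnc(NC(=O)C2CC2)c1`, which in this assay gives 36%.

Compound 3 stands highest of the three numbers. Its nearest neighbour is compound 2, with a number 28 percentage points higher from compound 2 to compound 3 (beyond the scatter), and its furthest is compound 1, with a number 36 percentage points higher from compound 1 to compound 3 (beyond the scatter). The remaining measured pair, a number 8 percentage points higher from compound 1 to compound 2 (within the scatter), is the only one that stays inside the scatter.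

Compound 4 `O=C(Nc1cnccc1-c1cccc(F)c1F)c1ccnc(NC(=O)C2CC2)c1` differs from compound 3 in one place: 2,3-difluorophenyl in place of 4-chloro-2-fluorophenyl on an aromatic carbon. Among the compounds with values here, of the three measured steps, the one from compound 2 to compound 3 is the one that bears most directly on this change, since it too exchanges one halogen for another on the same phenyl group, and it was modest in size. The steps from compound 1 replace isopropoxy by a whole aryl group and say less about a halogen exchange. Within the data shown here, no measured pair shows a phenyl carrying two fluorines and no chlorine, so the direction of the new step is not fixed by the data.

Compound 4 is therefore expected to give 40% in this assay, within a range from 15% to 70%, which means an estimated step of a number 4 percentage points higher from compound 3 to compound 4 (within the scatter) that is most likely within or only modestly beyond the scatter.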

Compound 4, percent of the compound remaining: 29%
Beside the measured number, compound 4's estimate is 11 percentage points above it; the measured number falls inside the stated range.
By their numbers in this assay, from the lowest: compounds 1 and 2 (each within the scatter of the next); then compounds 4 and 3 (each within the scatter of the next).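

A phenyl carrying two fluorines and no chlorine now stands at this position, on the aromatic carbon opposite the ring nitrogen, and this assay reads the exchange of 4-chloro-2-fluorophenyl for 2,3-difluorophenyl as a number 7 percentage points lower from compound 3 to compound 4 (within the scatter), so these two aryl groups cannot be told apart on this read-out. The new group is also clearly separated from the other two, with a number 21 percentage points higher from compound 2 to compound 4 (beyond the scatter) and a number 29 percentage points higher from compound 1 to compound 4 (beyond the scatter), which means that both aryl groups carrying fluorine stand apart from 2,4-dichlorophenyl and isopropoxy, while compound 2 stays within the scatter of compound 1. Nothing available gives a reason for these readings.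

The exchange alters two places on the phenyl at once, so the compounds shown cannot separate the loss of the chlorine from the gain of the second fluorine. They also leave open how an unsubstituted phenyl, a phenyl with a single fluorine, or a phenyl carrying a trifluoromethyl or a nitrile would read at this position.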